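Shortening an Iodoacetamide Linker on a Nucleotide Scaffold

The source may hold more compounds than are shown below. What is called first, only, known or untested is meant among the compounds shown, and "the series" means these compounds.

Three compounds have been measured in an assay on isolated protein for inhibition of hexokinase-1 (Rattus norvegicus), with a stated time of 6 h, tested at 10 mM; on this read-out higher numbers stand for more inhibition at the one concentration tested (going by the name of the read-out) and lower numbers for less inhibition:

compound 1 `O=C(CI)NCCCCC(=O)NCCCCCCNc1ncnc2c1ncn2[C@@H]1O[C@H](COP(=O)(O)OP(=O)(O)OP(=O)(O)O)[C@@H](O)[C@H]1O`: 0%
compound 2 `O=C(CI)NCCCCNc1ncnc2c1ncn2[C@@H]1O[C@H](COP(=O)(O)OP(=O)(O)OP(=O)(O)O)[C@@H](O)[C@H]1O`: 0%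
compound 3 `O=C(CI)NCCC(=O)NCCCCCCNc1ncnc2c1ncn2[C@@H]1O[C@H](COP(=O)(O)OP(=O)(O)OP(=O)(O)O)[C@@H](O)[C@H]1O`: 0%

All three share a nucleotide triphosphate core carrying a chain that ends in an iodoacetamide group, and in this assay none of them shows any measurable effect. Compound 1 and compound 3 differ in one place, (((iodomethyl)carbonyl)amino in place of 2-(((iodomethyl)carbonyl)amino)ethyl on a saturated chain carbon, two bonds along the chain from a carbonyl carbon), and the step of no change at the digits printed from compound 1 to compound 3 (within the scatter) shows that trimming the chain here makes no difference in this assay. The difference between the cores of compound 1 and compound 2 is not broken down here; a second single change, no change at the digits printed from compound 2 to compound 3 (within the scatter), likewise leaves the read-out where it was.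

Compound 4 `O=C(CI)NCCNc1ncnc2c1ncn2[C@@H]1O[C@H](COP(=O)(O)OP(=O)(O)OP(=O)(O)O)[C@@H](O)[C@H]1O` has not yet been measured. It arises from compound 2 by the same kind of change seen from compound 1 to compound 3: ((iodomethyl)carbonyl)amino in place of 2-(((iodomethyl)carbonyl)amino)ethyl on a saturated chain carbon, two bonds along the chain from a nitrogen on an aromatic ring. The surroundings differ, though: in the measured pair the change sits two bonds along the chain from a carbonyl carbon, whereas in the new pair it sits two bonds along the chain from a nitrogen on an aromatic ring.

Since every shortening or lengthening of the chain so far, including no change at the digits printed from compound 1 to compound 3 (within the scatter) and no change at the digits printed from compound 2 to compound 3 (within the scatter), has left the read-out unchanged, the step from compound 2 to compound 4 is expected to be about no change at the digits printed from compound 2 to compound 4 (within the scatter) in this assay. Compound 4 is therefore estimated to give about 0% in this assay, most likely between 0% and 10%.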

Compound 4, a percentage reported as inhibition, at one concentration (the size of the read-out at that concentration, not a potency): 0%
Estimate against measurement, compound 4: no gap at the digits printed, within the range that was stated.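

In this assay, putting ((iodomethyl)carbonyl)amino in place of 2-(((iodomethyl)carbonyl)amino)ethyl on the shorter-chained core gives no change at the digits printed from compound 2 to compound 4 (within the scatter), and set beside the same change on the other core, the two steps agree: the same change on two cores in this assay, no change at the digits printed (within the scatter) from compound 1 to compound 3 and no change at the digits printed (within the scatter) from compound 2 to compound 4, 0 percentage points apart, within the scatter of two such steps Within these four compounds, then, the change behaves alike on both cores, but only in the plain sense that it moves the read-out on neither. This does not show that an effect of the change carries from one core to another, since compound 4 gives 0% like the other three, so there is no effect of measurable size to carry, and a step of nothing cannot reveal whether the surrounding core would alter a real one.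

The compounds shown leave open whether a different end group, such as a maleimide or a plain amine in place of the iodoacetamide, or a chain longer than that of compound 1, would give any inhibition at all in this assay. Only with such a compound in hand could this shortening be tested for a real effect, and for whether that effect is the same on both cores.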